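This account rests on a few compounds, and the source may have more. Where it says the series, first, only, none or still open, it means among the compounds named here.

Working notes on the series. In a physicochemical assay for solubility, in phosphate buffer, measured as kinetic solubility, at pH 7.4 (a lower number here means a less soluble compound, a higher number a more soluble compound), compound 3 (`Cc1ccc(-c2nc(CN3CCC(C(=O)NCCCN4C[C@H](C)C[C@H](C)C4)CC3)c(C)o2)cc1C`) gives > 71 ug/mL, which is a limit and not a number. Compound 1 (`Cc1cccc(-c2nc(CN3CCC(C(=O)NCCCN4C[C@H](C)C[C@H](C)C4)CC3)c(C)o2)c1`) gives > 69 ug/mL, also a limit. Compound 2 (`COc1cccc(Br)c1-c1nc(CN2CCC(C(=O)NCCCN3C[C@H](C)C[C@H](C)C3)CC2)c(C)o1`) gives > 83 ug/mL, again a limit. Compound 3 therefore has no numeric standing within this set.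

Compound 4 (`Cc1cc(C)cc(-c2nc(CN3CCC(C(=O)NCCCN4C[C@H](C)C[C@H](C)C4)CC3)c(C)o2)c1`) has the same atoms as compound 3, joined differently: 3,5-dimethylphenyl in place of 3,4-dimethylphenyl on an aromatic carbon. The change is 3,5-dimethylphenyl in place of 3,4-dimethylphenyl on an aromatic carbon.

The closest measured change is a step that the two limits leave unreadable from compound 1 to compound 3, with methyl in place of hydrogen on an aromatic carbon. The other two are a step that the two limits leave unreadable from compound 1 to compound 2 and a step that the two limits leave unreadable from compound 2 to compound 3. None of them gives a size to carry over, so no step beyond the scatter is expected in this assay, in either direction. This expectation starts from compound 3 and its limit of > 71 ug/mL. The expected change is a number no higher from compound 3 to compound 4 (the limit leaves the size open). The estimate for compound 4 is 71 ug/mL, with an expected range of 50 ug/mL to 95 ug/mL, and the assay will probably report a limit again.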

Compound 4, solubility: > 71 ug/mL
Compound 4 gave a limit, no number (the forecaster's own chance of this, stated with the estimate: 85%); the middle value lies on the limit itself.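

In this assay, for the compounds shown here, compound 4 gives > 71 ug/mL, a limit, and compound 1, compound 2 and compound 3 also give limits, so no step between compound 4 and any of them can be read. The compounds shown leave open the actual values of all four compounds and the size of any step among them.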